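The source may report more compounds than this note shows. Statements on the series, on what has been measured and on what is new or still open speak of the compounds shown alone.

In an ADME assay on HEp-2 cells (Homo sapiens) for cytotoxicity, read by MTT assay, with a stated time of 3 days (a lower number here means that less compound is tolerated, a higher number that more compound is tolerated), compound 1 `CC[C@@H](CCn1cncn1)c1ccccc1` gives 89.9 ug/mL, and compound 2 `CCCC[C@H](CCn1cncn1)c1ccccc1` gives 50.2 ug/mL, the lower of the two numbers, although the gap to compound 1 lies within the usual scatter. Compound 3 `CCCC[C@@H](CCn1cncn1)c1ccccc1` follows from compound 2 by a single change: the two compounds have the same atoms and bonds and differ only in configuration as drawn: 1 of 1 stereo elements differ; a stereocentre at a saturated chain carbon is drawn R in compound 2 and S in compound 3. Going by the values given here, no pair of measured compounds differing in one place is available for comparison. For compound 3 no shift beyond the scatter is expected in this assay, in either direction, so the estimated step is a 1.0-fold lower number from compound 2 to compound 3 (0.00 log units; within the scatter). Compound 3 is therefore expected to give 50 ug/mL, within a range of 25 ug/mL to 100 ug/mL.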

Compound 3, half-maximal cytotoxic concentration: 40.8 ug/mL
The estimate for compound 3 lay 1.2-fold (0.09 log units) above the measured number, within the range that was stated.
By their numbers in this assay, from the lowest: compounds 3, 2 and 1 (each within the scatter of the next, the first and the last beyond it).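

In this assay, reversing the stereocentre at this saturated chain carbon produces no shift beyond the scatter (a 1.2-fold lower number from compound 2 to compound 3 (0.09 log units; within the scatter)), and this reading isolates configuration alone: the fact that compounds 2 and 3 differ only in the configuration as drawn. Ethyl in place of hydrogen on a saturated chain carbon, three bonds along the chain from an aromatic carbon, gives the only step here beyond the scatter, and a modest one (a 2.2-fold lower number from compound 1 to compound 3 (0.34 log units; beyond the scatter)). The compounds shown leave open whether configuration matters equally with the shorter chain of compound 1. They also leave open how a longer chain, or an amine or carboxylic acid on the chain, would read.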